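Dimethylamino in Place of Bromo: What to Expect

The source may report more compounds than this note shows. Statements on the series, on what has been measured and on what is new or still open speak of the compounds shown alone.

compound 1 `O=C(/C=C/c1ccc(Br)cc1)NS(=O)(=O)c1ccc(Cl)cc1`: 5.2 ug/mL
compound 2 `O=C(/C=C/c1ccc(Br)cc1)NS(=O)(=O)c1ccc(Br)cc1`: 5.1 ug/mL

In a functional assay on B16-F10 cells (Mus musculus) for antiproliferative activity, read by ELISA and MTT assay, with a stated time of 48 h (on this read-out lower numbers stand for stronger inhibition and higher numbers for weaker inhibition), compound 1 gives 5.2 ug/mL, the highest of the two numbers shown. Compound 2 gives 5.1 ug/mL, and the step of a 1.0-fold lower number from compound 1 to compound 2 (0.01 log units; within the scatter) lies within the scatter. Compound 3 `CN(C)c1ccc(/C=C/C(=O)NS(=O)(=O)c2ccc(Cl)cc2)cc1` differs from compound 1 by dimethylamino in place of bromo on an aromatic carbon. Within the data shown here, the only measured step, a 1.0-fold lower number from compound 1 to compound 2 (0.01 log units; within the scatter), alters the other ring and bears little on this change; no measured compound shows what dimethylamino does at this place. For compound 3 the expected step is therefore a 1.0-fold lower number from compound 1 to compound 3 (0.02 log units; within the scatter), none beyond the scatter in either direction. Compound 3 is estimated at 5 ug/mL, with a wide range from 1.5 ug/mL to 16 ug/mL.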

Compound 3, half-maximal inhibitory concentration: 2.8 ug/mL
The estimate for compound 3 lay 1.8-fold (0.25 log units) above the measured number; the range from low to high includes it.
By their numbers in this assay, from the lowest: compounds 3, 2 and 1 (each within the scatter of the next).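

In this assay putting dimethylamino in place of bromo on this aromatic carbon gives a 1.9-fold lower number from compound 1 to compound 3 (0.27 log units; within the scatter) and so no step beyond the scatter. The position therefore takes a group of three heavy atoms with one hydrogen-bond acceptor as well as a lone bromine, which compounds 1 and 2, both bromo here, could not show. No measurement among these compounds accounts for the result.

As far as these compounds go, whether a primary amine, a methoxy group or a carboxylic acid would also stay within the scatter here remains open. So does whether dimethylamino gives the same result with bromo on the other ring.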